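A few compounds are considered here, and "the series" means these few. Any claim that something is new, unique, unknown or untested is made for them only; others in the source may bear on it.

Measured so far in a functional assay on HBL-100 cells (Homo sapiens) for inhibition, read by sulforhodamine B assay, with a stated time of 48 h; on this read-out lower numbers stand for stronger inhibition of growth and higher numbers for weaker inhibition of growth:
Compound 1 `COC(=O)[C@@]1(C)CCC=C2[C@@H]1CC[C@@H](C)[C@]2(C)Cc1c[nH]c2ccc(C(F)(F)F)cc12` gives 15000 nM.
Compound 2 `COC(=O)[C@@]1(C)CCC=C2[C@@H]1CC[C@@H](C)[C@]2(C)Cc1c(C)[nH]c2ccc(F)cc12` gives 14000 nM.
Compound 3 `COC(=O)[C@@]1(C)CCC=C2[C@@H]1CC[C@@H](C)[C@]2(C)Cc1c(C)[nH]c2ccc(OC)cc12` gives 16000 nM.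

These three numbers sit close together: compound 3 differs from compound 1 and from compound 2 only within the usual scatter, so no order among them can be read. Compound 4 `COC(=O)[C@@]1(C)CCC=C2[C@@H]1CC[C@@H](C)[C@]2(C)Cc1c(C)[nH]c2ccc(C(F)(F)F)cc12` differs from compound 3 by trifluoromethyl in place of methoxy on an aromatic carbon. Among the measured compounds shown here, the one measured step at a ring substituent of this kind, a 1.1-fold higher number from compound 2 to compound 3 (0.06 log units; within the scatter), stayed within the scatter. Compound 1 already carries a trifluoromethyl on an aromatic carbon of the shared core and gives 15000 nM, in the same band. Compound 4 is therefore expected to stay in that band in this assay, with a step of a 1.1-fold lower number from compound 3 to compound 4 (0.03 log units; within the scatter) expected to lie within the scatter. Compound 4 is estimated at 15000 nM, between 7500 nM and 30000 nM.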

Compound 4, concentration for 50% growth inhibition: 16000 nM
Estimate against measurement, compound 4: 1.1-fold (0.03 log units) below; low and high end bracket the measured number.
By their numbers in this assay, from the lowest: compounds 2, 1, 3 and 4 (each within the scatter of the next).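

In this assay, the position carrying trifluoromethyl, methoxy or fluoro shows no readable preference: trifluoromethyl in place of methoxy (no change at the digits printed from compound 3 to compound 4 (within the scatter)) and trifluoromethyl in place of fluoro (a 1.1-fold higher number from compound 2 to compound 4 (0.06 log units; within the scatter)) both stay within the scatter. With trifluoromethyl kept, methyl in place of hydrogen at a second aromatic carbon of the shared core (a 1.1-fold higher number from compound 1 to compound 4 (0.03 log units; within the scatter)) also stays within the scatter. No supporting data explain this flat picture.

Going by these compounds, whether an amine, a carboxylic acid or a longer chain at the trifluoromethyl position would move the number out of this band remains open.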